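Trimming the side chain of an IDO1 inhibitor

The source may hold more compounds than are shown below. What is called first, only, known or untested is meant among the compounds shown, and "the series" means these compounds.

Compounds measured so far:
Compound 1, `NS(=O)(=O)CC(=O)NCCSc1nonc1/C(=N/O)Nc1ccc(F)c(Br)c1`, 12 nM
Compound 2, `C[C@@H](CSc1nonc1/C(=N/O)Nc1ccc(F)c(Br)c1)NC(=O)CS(N)(=O)=O`, 19 nM

In an assay for inhibition of Indoleamine 2,3-dioxygenase 1 (Homo sapiens), read by fluorescence, with a stated time of 24 h (on this read-out lower numbers stand for stronger inhibition and higher numbers for weaker inhibition), compound 1 gives 12 nM, the lowest of the two numbers recorded. Compound 2, which carries a methyl in place of hydrogen on a saturated chain carbon bound to an amide-type nitrogen and a saturated chain carbon, gives 19 nM; the step of a 1.6-fold higher number from compound 1 to compound 2 (0.20 log units; within the scatter) is within the scatter, so the two compounds cannot be told apart on this read-out.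

Compound 3, `CSc1nonc1/C(=N/O)Nc1ccc(F)c(Br)c1`, is a much smaller molecule. Relative to compound 1 it carries a hydrogen atom in place of a group of 9 heavy atoms (3 carbon, 2 nitrogen, 3 oxygen, 1 sulfur; no ring), on a saturated chain carbon bound to a sulfur. Only a short methylthio substituent remains on the shared core. For the measured compounds named here, no measured step touches this change: the one step recorded, from compound 1 to compound 2, alters a single methyl far out on the chain and says nothing about what the chain as a whole contributes. The expectation therefore rests on the size of the removal alone: a group this large is likely to matter, and a weaker result is estimated, with the step of a 5.0-fold higher number from compound 1 to compound 3 (0.70 log units; beyond the scatter) expected beyond the scatter. Compound 3 is estimated at 60 nM, with a range from 15 nM to 300 nM.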

Compound 3, half-maximal inhibitory concentration: 15 nM
Compound 3: the middle estimate sits 4.0-fold (0.60 log units) above what was measured, and the stated range covers the measured number.
By their numbers in this assay, from the lowest: compounds 1, 3 and 2 (each within the scatter of the next).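

In this assay, taking away the group of 9 heavy atoms on a saturated chain carbon bound to a sulfur gives a 1.3-fold higher number from compound 1 to compound 3 (0.10 log units; within the scatter), so the two compounds cannot be told apart on this read-out. The earlier methyl step touched only one carbon of the chain, whereas this change removes nearly all of it, along with its 2 hydrogen-bond donors and 3 hydrogen-bond acceptors, and shows that for this pair the short methylthio substituent on the shared core gives a number within the scatter of the one from the full chain. Nothing on hand explains why so large a removal leaves no readable difference.

The compounds shown leave open whether this position accepts almost anything or only certain groups, since a hydrogen in place of the large group and the large group itself are just two cases, and a simple amine, a carboxylic acid or a plain longer chain at the same place could give a different number. They also leave open whether the chain makes any difference outside this one read-out, which is the only one available here.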